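Trifluoromethyl to methyl in the step to compound 4

This account rests on a few compounds, and the source may have more. Where it says the series, first, only, none or still open, it means among the compounds named here.

In a physicochemical assay for lipophilicity, read by HPLC, at pH 7.4 (a lower number here means a more polar compound, a higher number a more lipophilic compound), compound 2 `CCC/N=C1\S/C(=C\c2ccc(O)c(C(F)(F)F)c2)C(=O)N1c1ccccc1C` gives 3.8, within the scatter of compound 1 `CCC/N=C1\S/C(=C\c2ccc(O)cc2)C(=O)N1c1ccccc1C` at 3.5. Compound 3 `Cc1ccccc1N1C(=O)/C(=C/c2ccc(O)c(Cl)c2)S/C1=N\CCCF` gives 3.4, a gap to compound 2 that lies beyond the scatter, but it differs from compound 2 in more than one place. Compound 4 `CCC/N=C1\S/C(=C\c2ccc(O)c(C)c2)C(=O)N1c1ccccc1C` has not been measured. Its difference from compound 2 is methyl in place of trifluoromethyl on an aromatic carbon, ortho to a hydroxy group. Among the compounds with values here, the one measured step bearing on this is a number 0.30 log units higher from compound 1 to compound 2 (within the scatter), with trifluoromethyl in place of hydrogen. Within the data shown here, no step involving methyl has been measured. The expected step is a number 0.20 log units lower from compound 2 to compound 4 (within the scatter), so no shift beyond the scatter is expected. For compound 4 the estimated value is 3.6, with an expected range of 3.3 to 3.9.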

Compound 4, distribution coefficient: 3.8
Beside the measured number, compound 4's estimate is 0.20 log units below it; measured number inside the range.
By their numbers in this assay, from the lowest: compounds 3, 1, 2 and 4 (each within the scatter of the next, the first and the last beyond it).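

In this assay, methyl in place of trifluoromethyl on this aromatic carbon, ortho to a hydroxy group, gives no change at the digits printed from compound 2 to compound 4 (within the scatter), so the size of the group leaving does not separate the two. Methyl in place of hydrogen on the same carbon gives a number 0.30 log units higher from compound 1 to compound 4 (within the scatter), so hydrogen, methyl and trifluoromethyl are not told apart here in this assay. Nothing at hand bears on why these groups read alike.

Open, from the compounds shown here alone, is whether a group of another kind on this carbon, such as an amine or a carboxylic acid, would give a step beyond the scatter. Going by these compounds, a longer chain there is equally open.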